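The source may report more compounds than this note shows. Statements on the series, on what has been measured and on what is new or still open speak of the compounds shown alone.

Measured so far in a functional assay on SK-BR-3 cells (Homo sapiens) for cytotoxicity, read by MTT assay, with a stated time of 72 h; a higher number here means a weaker inhibitor, a lower number a stronger inhibitor:
- compound 1 `CC(C)(C)OC(=O)N1CCN(c2c(C(=O)NCc3ccc(F)cc3)nc(Br)c3cccnc23)CC1`: 3000 nM
- compound 2 `Nc1ccc(Nc2c(C(=O)NCc3ccc(F)cc3)nc(Br)c3cccnc23)cc1`: 4000 nM
- compound 3 `CN(C)CCCNc1c(C(=O)NCc2ccc(F)cc2)nc(Br)c2cccnc12`: 1000 nM

Compound 3 has the lowest number of these three, which makes it the most potent so far in this assay. Compound 4 `O=C(NCc1ccc(F)cc1)c1nc(Br)c2cccnc2c1N1CCNCC1` has not yet been measured. It carries piperazin-1-yl in place of (3-(dimethylamino)propyl)amino on an aromatic carbon. Among the measured compounds shown here, the one measured step that changes this substituent is a 4.0-fold lower number from compound 2 to compound 3 (0.60 log units; beyond the scatter), and it is modest. Compound 1 also has a piperazine ring here, though a substituted one, and gives 3000 nM. Compound 4 is therefore expected to lose a little potency, probably without leaving the scatter. The expected change is a 1.5-fold higher number from compound 3 to compound 4 (0.18 log units; within the scatter). For compound 4 the estimated value is 1500 nM, with an expected range of 500 nM to 4500 nM.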

Compound 4, half-maximal inhibitory concentration: 6000 nM
Compound 4: the middle estimate sits 4.0-fold (0.60 log units) below what was measured, outside the stated range (above it).
By their numbers in this assay, from the lowest: compound 3; then compounds 1, 2 and 4 (each within the scatter of the next).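

In this assay, piperazin-1-yl in place of (3-(dimethylamino)propyl)amino gives a 6.0-fold higher number from compound 3 to compound 4 (0.78 log units; beyond the scatter) and so shows that this ring does not serve as well at this position as the open chain of compound 3. The tert-butoxycarbonyl group on the ring makes no clear difference, with a 2.0-fold higher number from compound 1 to compound 4 (0.30 log units; within the scatter) on its removal, and a 1.5-fold higher number from compound 2 to compound 4 (0.18 log units; within the scatter) leaves piperazin-1-yl and (4-aminophenyl)amino level. On these data alone, whether a shorter or longer chain ending in dimethylamino, or a morpholine ring, would match compound 3 remains open. Nothing measured here explains the loss.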